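This account rests on a few compounds, and the source may have more. Where it says the series, first, only, none or still open, it means among the compounds named here.

Compound 2 `c1ccc2c(-c3cn4ccnc4c(-c4ccc5ncn(C6CCCCC6)c5c4)n3)cccc2c1` gives the lowest of the two numbers seen so far: in a functional assay on OVCAR-3 cells (Homo sapiens) for inhibition, read by sulforhodamine B assay, with a stated time of 48 h, tested at 10 uM (on this read-out higher numbers stand for more inhibition at the one concentration tested (going by the name of the read-out) and lower numbers for less inhibition), compound 2 gives 2.38%, while compound 1 `Brc1cn2ccnc2c(-c2ccc3ncn(C4CCCCC4)c3c2)n1` gives 15.8% in this assay. Within the data shown here, the one measured step joining them, a number 13.4 percentage points lower from compound 1 to compound 2 (beyond the scatter), is the only guide available.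

Compound 3 `Fc1ccc(-c2cn3ccnc3c(-c3ccc4ncn(C5CCCCC5)c4c3)n2)cc1` differs from compound 2 in a single place: 4-fluorophenyl in place of naphthalen-1-yl on an aromatic carbon. Among the measured compounds shown here, no measured step involves 4-fluorophenyl, so the change cannot be read off directly. For the measured compounds named here, what the single known step does show is that enlarging the bromo position to naphthalen-1-yl moved the read-out downward; 4-fluorophenyl, with fewer heavy atoms and one aromatic ring rather than two, sits between bromo and naphthalen-1-yl in size, so the expectation is a number somewhere between the two measured values, most likely within the scatter of compound 2. The step expected from compound 2 to compound 3 in this assay is therefore a number 5.6 percentage points higher from compound 2 to compound 3 (within the scatter). Compound 3 is thus estimated at 8% in this assay, with a range from -5% to 22%.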

Compound 3, a percentage reported as inhibition, at one concentration (the size of the read-out at that concentration, not a potency): 7.88%
For compound 3 the middle estimate is 0.1 percentage points above the measured one; measured number inside the range.
By their numbers in this assay, from the lowest: compounds 2, 3 and 1 (each within the scatter of the next, the first and the last beyond it).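

In this assay, the result is a number 5.5 percentage points higher from compound 2 to compound 3 (within the scatter), and a number 7.9 percentage points lower from compound 1 to compound 3 (within the scatter), so 4-fluorophenyl cannot be told apart from either naphthalen-1-yl or bromo at this position. Taken alone, the earlier step from bromo to naphthalen-1-yl could suggest that the number simply drops as the group grows, but this new group, with one aromatic ring rather than two, neither confirms nor rules out that reading: only bromo and naphthalen-1-yl lie beyond the scatter of each other, and 4-fluorophenyl overlaps with both. Nothing available explains why these groups give the numbers they do.

Going by these compounds, all three groups carry no hydrogen-bond donors or acceptors by the counts for the two aryl groups compared here, so it remains open whether an amine, a carboxylic acid or a simple hydroxyl at this position would give a number clearly above that of bromo. Also open, on these data alone, is whether a small alkyl chain such as ethyl, with no aromatic ring at all, would behave like bromo or like the aryl groups.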